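The compounds below may be only part of what the source reports. "The series", "measured", "known", "first", "only" and "open" are said of these compounds alone.

Compound 1 `N#Cc1ccc(NC(=O)c2csc(Cc3c(Cl)cccc3Cl)n2)cc1` gives 450 nM in an assay on CHO cells, read by calcium flux; a higher number here means a weaker inhibitor, a lower number a stronger inhibitor. Compound 2 `COc1ccc(NC(=O)c2csc(Cc3c(Cl)cccc3Cl)n2)cn1` reaches only the limit > 4000 nM in this assay, so no number is known for it, and its true value sits beyond that limit (the limit of > 4000 nM in this assay, at which 1 of the 2 values shown sits).

Compound 3 `O=C(Nc1ccccc1Br)c1csc(Cc2c(Cl)cccc2Cl)n1` differs from compound 2 only in the group on the amide nitrogen: 2-bromophenyl in place of 6-methoxypyridin-3-yl on an amide-type nitrogen. Within the data shown here, the one measured step at this position, an at least 8.8-fold higher number from compound 1 to compound 2 (0.94 log units; beyond the scatter), shows that swapping the aromatic group there moves the result by at least a modest amount. Compound 3 is expected near 2000 nM, within 400 nM to 10000 nM, a step of an at least 2.0-fold lower number from compound 2 to compound 3 (0.30 log units; that floor lies within the scatter) estimated from the limit of compound 2.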

Compound 3, half-maximal inhibitory concentration: > 4000 nM
Compound 3: a limit, no number (the forecaster's own chance of this, stated with the estimate: 40%); middle value at least 2.0-fold (0.30 log units) away from the limit.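

Compound 3 gives a limit in this assay, not a number, and that limit is now shared: the limit of > 4000 nM in this assay, at which 2 of the 3 values shown sit.

Putting 2-bromophenyl in place of 4-cyanophenyl on the amide-type nitrogen gives an at least 8.8-fold higher number from compound 1 to compound 3 (0.94 log units; beyond the scatter), so a second, quite different group also falls short of the 4-cyanophenyl result. The step between the two limits cannot be read, so these two replacements cannot be ranked against each other.

Still open, as far as these compounds go, is whether the nitrile is what matters in 4-cyanophenyl, which an unsubstituted phenyl group could test. From the compounds shown here alone, whether any group on this nitrogen, such as a cyclohexyl group, can give a lower number than compound 1 also remains open.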